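From octylsulfanyl to pentyloxy on a shared core

The source may report more compounds than this note shows. Statements on the series, on what has been measured and on what is new or still open speak of the compounds shown alone.

Measured in an ADME assay on CCRF-HSB-2 cells (Homo sapiens) for cytotoxicity, with a stated time of 7 days; on this read-out lower numbers stand for higher toxicity in this test and higher numbers for lower toxicity in this test:
- compound 1 `Nc1nc(NCc2ccccc2)c2ncn(/C=C3/CC3(CO)CO)c2n1`: > 20000 nM (a limit)
- compound 2 `CCCNc1nc(N)nc2c1ncn2/C=C1/CC1(CO)CO`: > 20000 nM (a limit)
- compound 3 `CCCCCCCCSc1nc(N)nc2c1ncn2/C=C1/CC1(CO)CO`: 60000 nM

Within the data shown here, compound 3 holds the only actual number in this small set, at 60000 nM. Compound 1 reports only a limit, > 20000 nM. Compound 2 likewise reports only a limit, > 20000 nM. Together these two make up (the limit of > 20000 nM in this assay, at which 2 of the 3 values shown sit).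

The unmeasured compound 4 `CCCCCOc1nc(N)nc2c1ncn2/C=C1/CC1(CO)CO` carries pentyloxy in place of octylsulfanyl on an aromatic carbon.

Among the measured compounds shown here, no measured step gives a size for this change. The closest swap, also on an aromatic carbon, is a step that the limit leaves unreadable from compound 2 to compound 3. The same holds for a step that the limit leaves unreadable from compound 1 to compound 3, and also for a step that the two limits leave unreadable from compound 1 to compound 2. With no readable size to carry over, this assay gives no ground for expecting a move in either direction, and the value of compound 3 at 60000 nM remains the sole anchor. The estimated change is a 1.2-fold lower number from compound 3 to compound 4 (0.08 log units; within the scatter), which is expected to stay within the usual scatter. A reading reported only as a limit would also be unsurprising. For compound 4 the expected value is 50000 nM, with an estimated range from 20000 nM to 100000 nM.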

Compound 4, half-maximal cytotoxic concentration: > 20000 nM
Compound 4 ended at the assay's limit; the forecaster's own chance of this, stated with the estimate: 60%; the middle value is on the limit's open side.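

In this assay, among these compounds, compound 4 gives > 20000 nM, which is a limit and not a number, so no step linking it to compound 1, compound 2 or compound 3 can be read. Most of the set now shares one limit: the limit of > 20000 nM in this assay, at which 3 of the 4 values shown sit.

The compounds shown leave open whether pentyloxy in place of octylsulfanyl on an aromatic carbon changes the read-out at all.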